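From nitro to cyano on compound 3

The source may hold more compounds than are shown below. What is called first, only, known or untested is meant among the compounds shown, and "the series" means these compounds.

Among the measured compounds shown here, in a functional assay on T98G cells (Homo sapiens) for inhibition, read by MTT assay, with a stated time of 72 h (a higher number here means a weaker inhibitor, a lower number a stronger inhibitor), compound 3 `CC1(C)CC(NC(=S)Nc2cccc([N+](=O)[O-])c2)c2cc(Cl)ccc2O1` gives 4000 nM, the lowest of the three numbers so far. Compound 2 `CC1(C)CC(NC(=S)Nc2ccccc2)c2cc(Cl)ccc2O1` gives 37000 nM, and compound 1 `CC1(C)CC(NC(=S)Nc2cccc(C#N)c2)c2cc(F)ccc2O1` gives 39000 nM. Compound 4 `CC1(C)CC(NC(=S)Nc2cccc(C#N)c2)c2cc(Cl)ccc2O1` has cyano in place of nitro on an aromatic carbon, meta to a large group: cyano in place of nitro on an aromatic carbon. For the measured compounds named here, the one measured step bearing on this place is a 9.3-fold lower number from compound 2 to compound 3 (0.97 log units; beyond the scatter), a modest one with nitro replacing hydrogen. Compound 1 also carries cyano, yet its core differs and its number is high. Cyano is therefore expected to keep only part of that drop in this assay. The expected step, toward a higher number, is a 3.0-fold higher number from compound 3 to compound 4 (0.48 log units; beyond the scatter). For compound 4 the estimate is 12000 nM, within 4000 nM to 40000 nM.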

Compound 4, half-maximal inhibitory concentration: 10000 nM
For compound 4 the middle estimate is 1.2-fold (0.08 log units) above the measured one; the range from low to high includes it.
By their numbers in this assay, from the lowest: compound 3; then compound 4; then compounds 2 and 1 (each within the scatter of the next).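

In this assay, cyano on this aromatic carbon keeps part of the gain seen with nitro, with a 3.7-fold lower number from compound 2 to compound 4 (0.57 log units; beyond the scatter) against hydrogen, while the exchange of nitro for cyano gives a 2.5-fold higher number from compound 3 to compound 4 (0.40 log units; beyond the scatter) and so costs only part of that gain. With cyano held fixed, the halogen on the core also counts, as chloro in place of fluoro gives a 3.9-fold lower number from compound 1 to compound 4 (0.59 log units; beyond the scatter) for this pair. Nothing measured here accounts for either step.

From the compounds shown here alone, whether an amine or a carboxylic acid on this aromatic carbon would match nitro remains open. Also open, going by these compounds, is whether chloro in place of fluoro gives a similar step with nitro or hydrogen at this place.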